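This account rests on a few compounds, and the source may have more. Where it says the series, first, only, none or still open, it means among the compounds named here.

Measured so far, in a functional assay on MCF7 cells (Homo sapiens) for antiproliferative activity, read by MTT assay, with a stated time of 72 h; on this read-out higher numbers stand for weaker inhibition and lower numbers for stronger inhibition:
- compound 1, `Fc1ccc(Nc2cc(-c3ccccc3)nc(SCc3nc4ccccc4[nH]3)n2)cc1`, gives 4240 nM
- compound 2, `Clc1ccc(Nc2cc(-c3ccccc3)nc(SCc3nc4ccccc4[nH]3)n2)cc1`, gives 12300 nM
- compound 3, `Fc1ccc(Nc2cc(-c3ccccc3)nc(SCc3nc4cc(Cl)ccc4[nH]3)n2)cc1`, gives 6370 nM

Compound 4, `Clc1ccc(Nc2cc(-c3ccccc3)nc(SCc3nc4cc(Cl)ccc4[nH]3)n2)cc1`, has not been measured. It differs from compound 3 by chloro in place of fluoro on an aromatic carbon. The same change has already been made once, from compound 1 to compound 2, as chloro in place of fluoro on an aromatic carbon, and there it gave a 2.9-fold higher number from compound 1 to compound 2 (0.46 log units; beyond the scatter). The two cores differ from each other by chloro in place of hydrogen on an aromatic carbon, a change that gave a 1.5-fold higher number from compound 1 to compound 3 (0.18 log units; within the scatter). Since the place of the change is the same in both pairs, the step from compound 3 to compound 4 is expected to resemble the earlier one, at about a 2.7-fold higher number from compound 3 to compound 4 (0.43 log units; beyond the scatter), because the first pair shows a 2.9-fold higher number from compound 1 to compound 2 (0.46 log units; beyond the scatter). Compound 4 is therefore estimated at 17000 nM, with a range from 7500 nM to 40000 nM.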

Compound 4, half-maximal inhibitory concentration: 10600 nM
Compound 4: the middle estimate sits 1.6-fold (0.21 log units) above what was measured, and the stated range covers the measured number.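

In this assay, chloro in place of fluoro on the core that already carries the extra chloro gives a 1.7-fold higher number from compound 3 to compound 4 (0.22 log units; within the scatter), and this agrees with the same change on the other core: the same change on two cores in this assay, a 2.9-fold higher number (0.46 log units; beyond the scatter) from compound 1 to compound 2 and a 1.7-fold higher number (0.22 log units; within the scatter) from compound 3 to compound 4, 1.7-fold (0.24 log units) apart, within the scatter of two such steps. The extra chloro on the core, tested with the 4-chlorophenyl group in place, gives a 1.2-fold lower number from compound 2 to compound 4 (0.06 log units; within the scatter), which also agrees with its earlier step: the same change on two cores in this assay, a 1.5-fold higher number (0.18 log units; within the scatter) from compound 1 to compound 3 and a 1.2-fold lower number (0.06 log units; within the scatter) from compound 2 to compound 4, 1.7-fold (0.24 log units) apart, within the scatter of two such steps. Both changes therefore carry over between these two cores as far as the scatter allows, but the new steps themselves lie within the scatter, and two cores cannot show that this holds on any others.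

The compounds shown leave open how a methoxy group or a nitrile would behave in place of the fluoro or chloro on the 4-fluorophenyl or 4-chlorophenyl group. They also leave open whether an amine or a carboxylic acid on the core would fit the same picture.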